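Aryl swap on the ring amine nitrogen: compound 4

The compounds below may be only part of what the source reports. "The series", "measured", "known", "first", "only" and "open" are said of these compounds alone.

Compound 3 `COc1cc(OC)cc(N2CCN(C(=O)c3oc(C)nc3-c3ccccc3)CC2)c1` holds the lowest of the two numbers in a functional assay on HL-60 cells (Homo sapiens) for inhibition, read by MTT assay, with a stated time of 72 h; on this read-out higher numbers stand for weaker inhibition and lower numbers for stronger inhibition: compound 3 gives 19.2 nM. For the measured compounds named here, its nearest neighbour is compound 1 `Cc1nc(-c2ccccc2)c(C(=O)N2CCN(c3ccc(Cl)c(Cl)c3)CC2)o1`, which in this assay gives 124 nM; that pair forms the one measured step with a single change, a 6.5-fold lower number from compound 1 to compound 3 (0.81 log units; beyond the scatter). Compound 2 `COc1cccc(-c2nc(C)oc2C(=O)N2CCN(c3cccc(Cl)c3)CC2)c1` differs from compound 3 in two places; in this assay compound 2 is reported as "not active" (no number reported), a result without a number.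

Compound 4 `Cc1nc(-c2ccccc2)c(C(=O)N2CCN(c3cccc(Cl)c3)CC2)o1` differs from compound 3 in one place: 3-chlorophenyl in place of 3,5-dimethoxyphenyl on an amine nitrogen in a ring. Going by the values given here, the only step that bears on this is the one from compound 1 to compound 3, where 3,5-dimethoxyphenyl entering for 3,4-dichlorophenyl lowered the number; here the move runs back toward a chlorinated phenyl, so an upward step is expected, although the entering group is not the same one that left in that step. Compound 2, which also carries 3-chlorophenyl, gave no number, which leans the same way. The step from compound 3 to compound 4 is expected to be a 5.2-fold higher number from compound 3 to compound 4 (0.72 log units; beyond the scatter). Compound 4 is estimated at 100 nM in this assay, within a range from 30 nM to 400 nM.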

Compound 4, half-maximal inhibitory concentration: 39.2 nM
The estimate for compound 4 lay 2.6-fold (0.41 log units) above the measured number; low and high end bracket the measured number.
By their numbers in this assay, from the lowest: compound 3; then compound 4; then compound 1.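

On the ring amine nitrogen, 3-chlorophenyl keeps most of the activity in this assay: a 2.0-fold higher number from compound 3 to compound 4 (0.31 log units; beyond the scatter), so the 3,5-dimethoxyphenyl of compound 3 still gives the lowest number, but a chlorinated phenyl can come close, and dropping the chloro of the 3,4-dichlorophenyl group also helps, with a 3.2-fold lower number from compound 1 to compound 4 (0.50 log units; beyond the scatter). Compound 2 carries the same 3-chlorophenyl plus a methoxy on its other phenyl and is reported as "not active" (no number reported), so 3-chlorophenyl does not by itself go with the missing number. No measurement here explains either step.

The compounds shown leave open how an unsubstituted phenyl would compare at this position. They also leave open whether an amine or a carboxylic acid on this phenyl would be tolerated.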